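Changing the nitroimidazole chain from compound 3 to compound 4

This account rests on a few compounds, and the source may have more. Where it says the series, first, only, none or still open, it means among the compounds named here.

compound 1 `COc1cc2c(Nc3ccc(F)c(Cl)c3)ncnc2cc1OCCCn1ccnc1[N+](=O)[O-]` gives 6140 nM
compound 2 `C#Cc1cccc(Nc2ncnc3cc(OCCCCCn4ccnc4[N+](=O)[O-])c(OC)cc23)c1` gives 1310 nM
compound 3 `COc1cc2c(Nc3ccc(OCc4cccc(F)c4)c(Cl)c3)ncnc2cc1OCCCn1ccnc1[N+](=O)[O-]` gives 3790 nM

These numbers all come from a functional assay on HT-29 cells (Homo sapiens) for inhibition, read by sulforhodamine B assay, with a stated time of 72 h (on this read-out lower numbers stand for stronger inhibition and higher numbers for weaker inhibition), and can be compared directly. Compound 3 at 3790 nM lies within the scatter of compound 1 at 6140 nM while compound 2 shows a clearly lower number at 1310 nM on the same scale.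

Compound 4 `COc1cc2c(Nc3ccc(OCc4cccc(F)c4)c(Cl)c3)ncnc2cc1OCCOCCn1ccnc1[N+](=O)[O-]` alters only the chain of compound 3. The change is 2-(2-nitro-1H-imidazol-1-yl)ethoxy in place of (2-nitro-1H-imidazol-1-yl)methyl on a saturated chain carbon, two bonds along the chain from an oxygen on an aromatic ring and it sits on a saturated chain carbon, two bonds along the chain from an oxygen on an aromatic ring.

Going by the values given here, no measured pair isolates this change. Among the compounds with values here, the one measured step of a 1.6-fold lower number from compound 1 to compound 3 (0.21 log units; within the scatter) puts (3-fluorobenzyl)oxy in place of fluoro on an aromatic carbon and leaves the chain untouched, so it bears only indirectly, as a change elsewhere that stayed within the scatter. Compound 2 differs from compound 3 in both the chain and the aromatic group, so its number says nothing about the chain alone.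

With nothing pointing either way in this assay the expected step is a 1.1-fold lower number from compound 3 to compound 4 (0.03 log units; within the scatter) and no shift beyond the scatter is anticipated. For compound 4 the estimate is 3500 nM with an expected range from 1500 nM to 8000 nM until the measurement is known.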

Compound 4, half-maximal inhibitory concentration: 7640 nM
Compound 4: the middle estimate sits 2.2-fold (0.34 log units) below what was measured; the measured number falls inside the stated range.
By their numbers in this assay, from the lowest: compound 2; then compounds 3, 1 and 4 (each within the scatter of the next).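

In this assay, putting 2-(2-nitro-1H-imidazol-1-yl)ethoxy in place of (2-nitro-1H-imidazol-1-yl)methyl on a saturated chain carbon, two bonds along the chain from an oxygen on an aromatic ring, gives a 2.0-fold higher number from compound 3 to compound 4 (0.30 log units; within the scatter). This is the first pair shown that changes the chain alone, since the earlier step altered only the aromatic group, and it shows that this place accepts a larger group, of 11 heavy atoms rather than 9 and with one more oxygen, without a shift that can be told apart from repeat-to-repeat variation. Nothing available here offers an explanation for this result.

Still open, going by these compounds, is whether an amine in place of the ether oxygen, or a still longer chain, would move the number in this assay beyond the scatter. Also open is whether the same chain change would give a similar step on the fluoro-bearing aromatic group of compound 1, as the pair shown carries only the (3-fluorobenzyl)oxy group.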